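Adding methoxy to compound 3: working notes

A few compounds are considered here, and "the series" means these few. Any claim that something is new, unique, unknown or untested is made for them only; others in the source may bear on it.

In an ADME assay on microsomes from liver (Mus musculus) for metabolic stability, read by LC-MS, using NADPH, tested at 4.6 uM (a lower number here means that the compound disappears faster, a higher number that the compound lasts longer), compound 1 `CCCCCNC(=O)n1cc(-c2ccccc2)oc1=O` gives < 0.0834 h, which is a limit of the assay and not a number. Compound 2 `CC(C)CNC(=O)n1cc(-c2ccccc2)oc1=O` gives 0.833 h. Compound 3 `O=C(NCCCCc1ccccc1)n1cc(-c2ccc(F)cc2)oc1=O` gives 1 h, within the scatter of compound 2. Compound 4 `COc1cc(-c2cn(C(=O)NCCCCc3ccccc3)c(=O)o2)ccc1F` differs from compound 3 by methoxy in place of hydrogen on an aromatic carbon, ortho to a fluoro group. Among the measured compounds shown here, the only measured step, an at least 9.9-fold higher number from compound 1 to compound 2 (0.99 log units; beyond the scatter), rests on the limit of < 0.0834 h in this assay, at which 1 of the 3 values shown sits, and lies in the chain on the amide-type nitrogen, so it gives no size for a change on the aromatic ring. No change beyond the scatter is therefore expected, and the expected step is a 1.4-fold lower number from compound 3 to compound 4 (0.15 log units; within the scatter). Compound 4 is estimated at 0.7 h, with an expected range of 0.25 h to 1.6 h.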

Compound 4, half-life: > 1 h
Compound 4 was reported as a limit; the forecaster's own chance of this, stated with the estimate: 10%; middle value at least 1.4-fold (0.15 log units) away from the limit.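

In this assay compound 4 gives > 1 h, which is a limit of the assay and not a number. Methoxy in place of hydrogen, ortho to a fluoro group, gives a number no lower from compound 3 to compound 4 (the limit leaves the size open), so in this series this aromatic carbon carries the group with no loss of half-life. How much longer the half-life is cannot be read, because the result sits at a limit: the limit of > 1 h in this assay, at which 1 of the 4 values shown sits.

Going by these compounds, whether an amine or a carboxylic acid on this same carbon would leave the half-life as intact remains open. Also open, on these data alone, is whether methoxy would give the same result with the shorter chains on the amide-type nitrogen.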